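The source may hold more compounds than are shown below. What is called first, only, known or untested is meant among the compounds shown, and "the series" means these compounds.

Measured in (a functional assay on a cell-free system (Platelet, plasma, Oryctolagus cuniculus) for inhibition, with a stated time of 5 min, at 37 degrees C; on this read-out lower numbers stand for stronger inhibition and higher numbers for weaker inhibition)
- compound 1 `Cc1nc(C)c(C(=O)Oc2ccccc2/C=C/C(=O)O)nc1C` gives 9600 nM
- compound 2 `COc1ccc(OC(=O)c2nc(C)c(C)nc2C)c(/C=C/C(=O)O)c1` gives 49000 nM
- compound 3 `Cc1nc(C)c(C(=O)Oc2ccc(Cl)cc2/C=C/C(=O)O)nc1C` gives 57200 nM

Compound 3 does not separate from compound 2 (a 1.2-fold higher number from compound 2 to compound 3 (0.07 log units; within the scatter)), while compound 1 gives the lower number (a 6.0-fold higher number from compound 1 to compound 3 (0.78 log units; beyond the scatter)).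

Compound 4 `CCOC(=O)/C=C/c1cc(Cl)ccc1OC(=O)c1nc(C)c(C)nc1C` differs from compound 3 by one change (ethyl in place of hydrogen on an oxygen next to a carbonyl group), which reads carboxy to ethoxycarbonyl. Among the compounds with values here, no measured step touches the carboxy group. Within the data shown here, the only steps available are modest changes on an aromatic carbon (a 5.1-fold higher number from compound 1 to compound 2 (0.71 log units; beyond the scatter)) and (a 6.0-fold higher number from compound 1 to compound 3 (0.78 log units; beyond the scatter)), and these give no direction for this change. In this assay, on these data alone, no shift beyond the scatter is therefore expected, though a modest step either way remains open. The estimated step is small (a 1.0-fold higher number from compound 3 to compound 4 (0.02 log units; within the scatter)). For compound 4 the expected value is 60000 nM with an estimated range from 15000 nM to 240000 nM.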

Compound 4, half-maximal inhibitory concentration: 67100 nM
Beside the measured number, compound 4's estimate is 1.1-fold (0.05 log units) below it; measured number inside the range.
By their numbers in this assay, from the lowest: compound 1; then compounds 2, 3 and 4 (each within the scatter of the next).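

Within the data shown here, this is the first step at the carboxy group: in this assay, ethyl in place of hydrogen on an oxygen next to a carbonyl group gives a 1.2-fold higher number from compound 3 to compound 4 (0.07 log units; within the scatter). With the chloro group in place, the carboxy and ethoxycarbonyl forms therefore do not separate on this read-out. No measurement at hand offers an explanation for this result.

On these data alone, it remains open whether the same change reads alike on compound 1, which carries no chloro group. Also open, as far as these compounds go, is how a primary amide in place of the carboxy group, or a chain longer than ethyl, would read.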